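Changing the Group on the Carbonyl Carbon of Compound 1

The source may hold more compounds than are shown below. What is called first, only, known or untested is meant among the compounds shown, and "the series" means these compounds.

Measured so far:
Compound 1, `COc1ccc(C(=O)/C=C/c2nc3ccccc3cc2-c2ccc(OC)cc2)cc1`: 8500 nM
Compound 2, `COc1ccc(-c2cc3ccccc3nc2/C=C/C(=O)c2ccc(Br)s2)cc1`: 6250 nM

Of the compounds shown here, two have been measured in a functional assay on A549 cells (Homo sapiens) for antiproliferative activity, read by XTT assay, with a stated time of 72 h; on this read-out higher numbers stand for weaker inhibition and lower numbers for stronger inhibition. Compound 1 `COc1ccc(C(=O)/C=C/c2nc3ccccc3cc2-c2ccc(OC)cc2)cc1` gives 8500 nM, and compound 2 `COc1ccc(-c2cc3ccccc3nc2/C=C/C(=O)c2ccc(Br)s2)cc1` gives 6250 nM. Of these two numbers, compound 1 stands highest; compound 2 is the nearer and only neighbour, and the step of a 1.4-fold lower number from compound 1 to compound 2 (0.13 log units; within the scatter) is too small to be told apart from repeat measurements.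

Compound 3 `COc1ccc(-c2cc3ccccc3nc2/C=C/C(=O)c2cnc(N)nc2C)cc1` has not yet been measured. It differs from compound 1 by 2-amino-4-methylpyrimidin-5-yl in place of 4-methoxyphenyl on a carbonyl carbon. For the measured compounds named here, the one measured step that bears on this exchange, at the same place, is a 1.4-fold lower number from compound 1 to compound 2 (0.13 log units; within the scatter), which stayed within the scatter. Because of that small step a 1.4-fold lower number from compound 1 to compound 2 (0.13 log units; within the scatter), compound 3 is expected to land close to compound 1, though the group that enters here is unlike either group measured so far, so the range is kept wide. Compound 3 is therefore expected to give 7000 nM, between 2500 nM and 20000 nM. Compound 3 is thus expected to show a 1.2-fold lower number from compound 1 to compound 3 (0.08 log units; within the scatter), no step beyond the scatter.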

Compound 3, half-maximal inhibitory concentration: > 10000 nM
Compound 3: no number, only a limit; the forecaster's own chance of this, stated with the estimate: 10%; at least 1.4-fold (0.15 log units) between middle value and limit.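

In this assay compound 3 carries a limit of the assay and not a number: the limit of > 10000 nM in this assay, at which 1 of the 3 values shown sits. Measured against the groups that leave, the entry of 2-amino-4-methylpyrimidin-5-yl on the carbonyl carbon gives an at least 1.1-fold higher number from compound 1 to compound 3 (0.07 log units; that floor lies within the scatter) and an at least 1.6-fold higher number from compound 2 to compound 3 (0.20 log units; that floor lies within the scatter), so these floors alone do not set compound 3 apart from either earlier compound, although its true value may lie well beyond them. For the compounds shown here, what is new is that this place has now held a third, quite different ring, one with hetero atoms and an amine on it, and for the first time the read-out gives only a limit rather than a number.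

The compounds shown leave open how far past its limit compound 3 lies, and whether the ring nitrogen atoms, the amine or the methyl group matters most for this outcome. A pyrimidin-5-yl ring with neither the amine nor the methyl group, or a 4-aminophenyl group on the same carbonyl carbon, would begin to pull these parts apart.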